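This account rests on a few compounds, and the source may have more. Where it says the series, first, only, none or still open, it means among the compounds named here.

Measured compounds:
- compound 1, `O=C(NO)c1ccc(CN(Cc2ccccc2)S(=O)(=O)c2c(F)c(F)c(F)c(F)c2F)cc1`: 150 nM
- compound 2, `CN(C)c1ccc(CN(Cc2ccc(C(=O)NO)cc2)S(=O)(=O)c2c(F)c(F)c(F)c(F)c2F)cc1`: > 1000 nM

In an assay on isolated protein for inhibition of histone deacetylase 8 (Homo sapiens), read by mobility shift assay (a lower number here means a stronger inhibitor, a higher number a weaker inhibitor), compound 1 gives 150 nM. For compound 2 the assay reports only a limit, > 1000 nM, and not a number. Compound 1 thus holds the only actual number shown in this assay, the one other value being a limit.

Within the data shown here, the single measured step, an at least 6.6-fold higher number from compound 1 to compound 2 (0.82 log units; beyond the scatter), is the change from compound 1 to compound 2; it reaches the limit (the limit of > 1000 nM in this assay, at which 1 of the 2 values shown sits), so its true size is only bounded from below.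

Compound 3, `O=C(NO)c1ccc(CN(Cc2ccccc2)S(=O)(=O)c2cc(F)c(F)c(F)c2F)cc1`, differs from compound 1 in one place: hydrogen in place of fluoro on an aromatic carbon. Among the measured compounds shown here, no measured step touches this ring, so the step from compound 1 to compound 2 bears on compound 3 only as a reminder that one change on the shared core can move the number well beyond the scatter. For the loss of a single fluoro from the pentafluorophenyl group, compound 3 is expected to give 250 nM, within 80 nM to 800 nM, an estimated 1.7-fold higher number from compound 1 to compound 3 (0.22 log units; within the scatter).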

Compound 3, half-maximal inhibitory concentration: 155 nM
Compound 3: middle estimate off by 1.6-fold (0.21 log units), on the high side; low and high end bracket the measured number.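

In this assay, exchanging 2,3,4,5,6-pentafluorophenyl for 2,3,4,5-tetrafluorophenyl gives a 1.0-fold higher number from compound 1 to compound 3 (0.01 log units; within the scatter), so at this position, ortho to a large group, hydrogen can stand in place of fluoro without a change that can be told from the scatter. Among these compounds, the only earlier step lay elsewhere on the shared core and ended at a limit of the assay, so this is the first step on the fluorinated ring and the first step that can be read between two actual numbers. Nothing given here accounts for this result.

The compounds shown leave open whether the flat result holds for the remaining fluoro groups, taken away singly or together, since only one fluoro has been exchanged and only for hydrogen. They also leave open what a group other than hydrogen would do at this position, such as a chlorine atom, a methoxy group, a nitrile, an amine or a carboxylic acid, and whether such a group would move the number beyond the scatter.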